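A few compounds are considered here, and "the series" means these few. Any claim that something is new, unique, unknown or untested is made for them only; others in the source may bear on it.

Compound 2 `CC1(C)CCC(C)(C)c2cc(C(=O)/C=C/c3c[nH]c4ccc(Br)cc34)ccc21` is a close relative of compound 1 `CC1(C)CCC(C)(C)c2cc(C(=O)/C=C/c3c[nH]c4ccccc34)ccc21`. In a functional assay on Huh-7 cells (Homo sapiens) for cytotoxicity, read by sulforhodamine B assay, with a stated time of 3 days (a higher number here means a weaker inhibitor, a lower number a stronger inhibitor), compound 1 gives only a limit, < 10 nM, as the value sits at the limit of < 10 nM in this assay, at which 1 of the 2 values shown sits. In this assay, for the measured compounds named here, compound 2 gives 14000 nM, the only plain number among the values shown here. Going by the values given here, the one measured step, an at least 1400-fold higher number from compound 1 to compound 2 (3.14 log units; beyond the scatter), shows that a group on this carbon can weaken the activity greatly, but no measured step swaps one group for another there. Compound 3 `CC1(C)CCC(C)(C)c2cc(C(=O)/C=C/c3c[nH]c4ccc(C(=O)O)cc34)ccc21` has not yet been measured in this assay; it differs from compound 2 in one place: carboxy in place of bromo on an aromatic carbon. Among the compounds with values here, because the bromo change in an at least 1400-fold higher number from compound 1 to compound 2 (3.14 log units; beyond the scatter) is the only guidance, the direction of the new step is uncertain, and the expected step of a 1.4-fold lower number from compound 2 to compound 3 (0.15 log units; within the scatter) is kept small against that uncertainty. Compound 3 is therefore estimated at 10000 nM in this assay, within a range from 1000 nM to 50000 nM.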

Compound 3, half-maximal inhibitory concentration: "not active" (no number reported)
Compound 3 has no reported number here; the estimate stays without a comparison.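

In this assay, for the compounds shown here, compound 3 is reported only as "not active", without a number, so no step from compound 2 to compound 3 can be read. What stays open is how carboxy and bromo on this carbon compare, and the exact size of the change from compound 1, whose value is a limit: the limit of < 10 nM in this assay, at which 1 of the 3 values shown sits.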